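Adding a Dimethylamino Group to the Benzyl Arm

The source may report more compounds than this note shows. Statements on the series, on what has been measured and on what is new or still open speak of the compounds shown alone.

Measured compounds:
Compound 1, `CCN(CCCCOc1ccc(C(=O)/C=C/c2ccc(N(C)C)cc2)c(O)c1)Cc1ccccc1`: in an assay on isolated protein for inhibition of Amine oxidase [flavin-containing] A (Homo sapiens) (a higher number here means a weaker inhibitor, a lower number a stronger inhibitor), compound 1 gives 77300 nM.
Compound 2, `CCN(CC)CCCOc1ccc(C(=O)/C=C/c2ccc(N(C)C)cc2)c(O)c1`: in this assay compound 2 gives 47100 nM.
Compound 3, `CCN(CCCOc1ccc(C(=O)/C=C/c2ccc(N(C)C)cc2)c(O)c1)Cc1ccccc1`: in this assay compound 3 gives 82600 nM.

Compound 1 stands second highest of these three numbers, and all three lie within the usual scatter of one another: a 1.6-fold lower number from compound 1 to compound 2 (0.22 log units; within the scatter), a 1.1-fold higher number from compound 1 to compound 3 (0.03 log units; within the scatter), and a 1.8-fold higher number from compound 2 to compound 3 (0.24 log units; within the scatter). The new compound 4, `CCN(CCCCOc1ccc(C(=O)/C=C/c2ccc(N(C)C)cc2)c(O)c1)Cc1ccc(N(C)C)cc1`, differs from compound 1 in one place: dimethylamino in place of hydrogen on an aromatic carbon, so that the benzyl on the amine nitrogen becomes a 4-(dimethylamino)benzyl. For the measured compounds named here, none of the measured steps places anything on that ring. The nearest comparisons are the phenyl in place of methyl on the carbon bound to the amine nitrogen, a 1.8-fold higher number from compound 2 to compound 3 (0.24 log units; within the scatter), and the two changes in the chain that carries the amine, which also stayed within the scatter. Changes around this amine have so far left the numbers essentially unmoved, so the step is expected to stay within the scatter: a 1.1-fold lower number from compound 1 to compound 4 (0.04 log units; within the scatter). Compound 4 is therefore estimated at 70000 nM, with a range from 25000 nM to 200000 nM.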

Compound 4, half-maximal inhibitory concentration: 17200 nM
The estimate for compound 4 lay 4.1-fold (0.61 log units) above the measured number; measured number below the stated range.
By their numbers in this assay, from the lowest: compound 4; then compounds 2, 1 and 3 (each within the scatter of the next).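

The benzyl ring on the amine nitrogen proves to be a place where a change registers in this assay: dimethylamino in place of hydrogen on an aromatic carbon, para to a large group, gives a modest drop in the number (a 4.5-fold lower number from compound 1 to compound 4 (0.65 log units; beyond the scatter)). For the compounds shown here, this is the first step here to go beyond the scatter, whereas the steps among compound 1, compound 2 and compound 3 all stayed within it. Nothing available here bears on what lies behind this drop.

As far as these compounds go, it remains open whether the drop is tied to dimethylamino itself or would also come with another group on that ring carbon, such as methoxy, a plain amino group or chlorine. From the compounds shown here alone, it is also open whether dimethylamino on the benzyl of compound 3 would give a step of similar size.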